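The source may report more compounds than this note shows. Statements on the series, on what has been measured and on what is new or still open speak of the compounds shown alone.

Measured compounds:
Compound 1, `CCCCC#Cc1cn([C@H]2C[C@H](O)[C@@H](CO)O2)c(=O)[nH]c1=O`, gives 1000 ug/mL.
Compound 2, `CCC#Cc1cn([C@H]2C[C@H](O)[C@@H](CO)O2)c(=O)[nH]c1=O`, gives > 1000 ug/mL, which is a limit of the assay.
Compound 3, `CCCC#Cc1cn([C@H]2C[C@H](O)[C@@H](CO)O2)c(=O)[nH]c1=O`, gives > 1000 ug/mL, which is likewise a limit of the assay.

All three were tested in a functional assay on L1210 cells (Mus musculus); a higher number here means a weaker inhibitor, a lower number a stronger inhibitor. For the measured compounds named here, compound 1 is the only one with a number; for compound 2 and for compound 3 the assay reports only a limit. The step of a number no lower from compound 1 to compound 2 (the limit leaves the size open) therefore has no readable size; its change is hydrogen in place of ethyl on a saturated chain carbon, two bonds along the chain from a triple-bonded carbon. In the same way a number no lower from compound 1 to compound 3 (the limit leaves the size open) is left open, with the change (hydrogen in place of methyl on a saturated chain carbon, three bonds along the chain from a triple-bonded carbon), which is also how the core of compound 3 differs from the core of compound 1. Between the two limits, a step that the two limits leave unreadable from compound 2 to compound 3 cannot be read at all.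

Compound 4, `CC#Cc1cn([C@H]2C[C@H](O)[C@@H](CO)O2)c(=O)[nH]c1=O`, has not yet been measured in this assay. It arises from compound 3 by hydrogen in place of ethyl on a saturated chain carbon bound to a triple-bonded carbon. Going by the values given here, this is the same kind of change as the one from compound 1 to compound 2, though the place differs: there the hydrogen entered two bonds along the chain from a triple-bonded carbon, here it enters on a saturated chain carbon bound to a triple-bonded carbon. That earlier step, a number no lower from compound 1 to compound 2 (the limit leaves the size open), did not lower the value, and the limit of > 1000 ug/mL in this assay, at which 2 of the 3 values shown sit, shows where most of the series sits. Compound 4 is therefore expected to show a step of a number no higher from compound 3 to compound 4 (the limit leaves the size open), resting on the step of a number no lower from compound 1 to compound 2 (the limit leaves the size open) that gave no downward movement. For compound 4 the estimate is 1000 ug/mL, between 500 ug/mL and 2000 ug/mL, with a good chance that the assay again reports only a limit.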

Compound 4, concentration for 50% inhibition: 164 ug/mL
Compound 4: middle estimate off by 6.1-fold (0.79 log units), on the high side, outside the stated range (below it).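

In this assay, an at least 6.0-fold lower number from compound 3 to compound 4 (0.78 log units; beyond the scatter), and both an at least 6.0-fold lower number from compound 2 to compound 4 (0.78 log units; beyond the scatter) and a 6.1-fold lower number from compound 1 to compound 4 (0.79 log units; beyond the scatter) point the same way, so in this series the loss of chain carbons does not carry from one core to another with the same result: the same change on two cores in this assay, a number no lower (the limit leaves the size open) from compound 1 to compound 2 and an at least 6.0-fold lower number (0.78 log units; beyond the scatter) from compound 3 to compound 4, at least 6.0-fold (0.78 log units) apart, beyond the scatter of two such steps

The second pair of matching changes gives the same answer: the same change on two cores in this assay, a number no lower (the limit leaves the size open) from compound 1 to compound 3 and an at least 6.0-fold lower number (0.78 log units; beyond the scatter) from compound 2 to compound 4, at least 6.0-fold (0.78 log units) apart, beyond the scatter of two such steps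

This shows only that the prop-1-yn-1-yl chain of compound 4 departs from the other three compounds; the steps among compounds 1, 2 and 3 that end at a limit cannot be read, so the true size of the gaps stays open, and the data give no cause for the difference: the limit of > 1000 ug/mL in this assay, at which 2 of the 4 values shown sit.

Left open is how a plain ethynyl group, with hydrogen in place of the methyl of compound 4, would read, and whether a chain longer than that of compound 1 would stay near compound 1. Also open, from the compounds shown here alone, is what an amine or a hydroxyl group at the end of the chain would do on the shared core.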